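The compounds below may be only part of what the source reports. "The series", "measured", "known", "first", "only" and "open" are said of these compounds alone.

Three compounds share one core and differ only in the group attached to the sulfonyl sulfur. Compound 1 `CC(C)NCCS(=O)(=O)NC(=O)c1ccc(Nc2nc(NC3(c4ccc(Cl)cc4)CC3)nc(OCC(F)(F)F)n2)cc1` gives 45 nm/s in a physicochemical assay for permeability, using PAMPA, at pH 7.4; on this read-out higher numbers stand for higher permeability and lower numbers for lower permeability. Compound 2 `CCS(=O)(=O)NC(=O)c1ccc(Nc2nc(NC3(c4ccc(Cl)cc4)CC3)nc(OCC(F)(F)F)n2)cc1` gives 28 nm/s in this assay, and the step of a 1.6-fold lower number from compound 1 to compound 2 (0.21 log units; within the scatter) is within the scatter. Compound 3 `O=C(NS(=O)(=O)CCNC(=O)C1CC1)c1ccc(Nc2nc(NC3(c4ccc(Cl)cc4)CC3)nc(OCC(F)(F)F)n2)cc1` gives 1 nm/s in this assay, the lowest of the three numbers: the step of a 45-fold lower number from compound 1 to compound 3 (1.65 log units; beyond the scatter) and the step of a 28-fold lower number from compound 2 to compound 3 (1.45 log units; beyond the scatter) are both large and beyond the scatter, and in each the chain that ends in a (cyclopropylcarbonyl)amino group is what sets compound 3 apart.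

Compound 4 `Cc1ccccc1S(=O)(=O)NC(=O)c1ccc(Nc2nc(NC3(c4ccc(Cl)cc4)CC3)nc(OCC(F)(F)F)n2)cc1` has not yet been measured. It differs from compound 3 in one place: 2-methylphenyl in place of 2-((cyclopropylcarbonyl)amino)ethyl on a sulfonyl sulfur. The group that leaves is the one that carries the hydrogen-bond donor and acceptor of the chain, and a group with no donor and no acceptor enters; compound 3's chain is the same feature that, in the steps from compound 1 and compound 2, went with a large fall in the number. Within the data shown here, the step of a 40-fold higher number from compound 3 to compound 4 (1.60 log units; beyond the scatter) is therefore expected to be a large rise in this assay, although the exact landing point is uncertain because no measured compound carries an aryl group on the sulfonyl sulfur. Compound 4 is expected to give about 40 nm/s in this assay, with a range from 8 nm/s to 200 nm/s.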

Compound 4, apparent permeability: 265 nm/s
For compound 4 the middle estimate is 6.6-fold (0.82 log units) below the measured one; measured number outside the range, above it.
By their numbers in this assay, from the lowest: compound 3; then compounds 2 and 1 (each within the scatter of the next); then compound 4.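

On a sulfonyl sulfur, 2-methylphenyl gives the highest number of the four compounds in this assay, with a 270-fold higher number from compound 3 to compound 4 (2.42 log units; beyond the scatter) in place of 2-((cyclopropylcarbonyl)amino)ethyl, a 9.5-fold higher number from compound 2 to compound 4 (0.98 log units; beyond the scatter) in place of ethyl, and a 5.9-fold higher number from compound 1 to compound 4 (0.77 log units; beyond the scatter) in place of 2-(isopropylamino)ethyl, all of them beyond the scatter. The earlier compounds shown here showed this position only as a place where the number could fall from the level shared, within the scatter, by compound 1 and compound 2; compound 4 shows that a change here can also lift the number clear of that level, and that a ring of carbon on the sulfur is compatible with such a rise. Nothing measured in this set speaks to the reason for these steps.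

With a single aryl group in the set, the compounds shown leave open whether the rise goes with the six-membered aromatic ring itself or with its methyl group. A plain phenyl group and a saturated cyclohexyl ring on the same sulfonyl sulfur would begin to separate those two readings.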